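This account rests on a few compounds, and the source may have more. Where it says the series, first, only, none or still open, it means among the compounds named here.

In an ADME assay on the whole organism (plasma, Rattus norvegicus) for protein binding, using cassette dosing, at a dose of 1 mg/kg (on this read-out lower numbers stand for a smaller free fraction and higher numbers for a larger free fraction), compound 1 `C[C@@H](Cn1c(=O)[nH]/c(=N\c2ccc(Oc3cncc(F)c3)cc2)n(Cc2ccc(Cl)cc2)c1=O)C(=O)O` gives 0.02 and compound 2 `C[C@@H](Cn1c(=O)[nH]/c(=N\c2ccc(Oc3ccsn3)cc2)n(Cc2ccc(Cl)cc2)c1=O)C(=O)O` gives 0.012. Among the measured compounds shown here, these two numbers cannot be told apart, so compound 2 stands level with the only other measured compound. Compound 3 `C[C@@H](Cn1c(=O)[nH]/c(=N\c2ccc(OC3CCC3)cc2)n(Cc2ccc(Cl)cc2)c1=O)C(=O)O` keeps the shared core and changes one group: cyclobutyl in place of 1,2-thiazol-3-yl on an oxygen on an aromatic ring. In short, cyclobutyl comes in place of 1,2-thiazol-3-yl on an oxygen on an aromatic ring.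

For the measured compounds named here, only one measured step bears on this change. It is an exchange at the same place, and it amounts to a 1.7-fold lower number from compound 1 to compound 2 (0.22 log units; within the scatter). That exchange swapped one aromatic ring for another, whereas cyclobutyl is a non-aromatic ring of carbon only, so it is an imperfect guide. No shift beyond the scatter is therefore expected, in either direction. The expected step is no change at the digits printed from compound 2 to compound 3 (within the scatter). For compound 3 the estimated value is 0.012, with a range of 0.005 to 0.03.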

Compound 3, unbound fraction: 0.015
Compound 3: the middle estimate sits 1.3-fold (0.10 log units) below what was measured; low and high end bracket the measured number.
By their numbers in this assay, from the lowest: compounds 2, 3 and 1 (each within the scatter of the next).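

In this assay the exchange for cyclobutyl, a non-aromatic ring of carbon only with no hydrogen-bond acceptors, gives a 1.3-fold higher number from compound 2 to compound 3 (0.10 log units; within the scatter) and a 1.3-fold lower number from compound 1 to compound 3 (0.12 log units; within the scatter) and so stays within the scatter on both counts. The earlier step only swapped one aromatic ring for another, whereas these compounds show that, on this oxygen, an aromatic ring with hetero atoms is not needed to keep the number in the same range. No measurement available here explains this result.

Going by these compounds, it remains open whether a different kind of group on this oxygen, such as an amine or a carboxylic acid, would move the number beyond the scatter. The same question holds for a longer open carbon chain, which would have no ring at all.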